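4-methylphenyl to 2-chlorophenyl: one swap, one open number

The compounds below may be only part of what the source reports. "The series", "measured", "known", "first", "only" and "open" are said of these compounds alone.

Compound 1 `CC(=O)Nc1ccc(/C=C2/S/C(=N/c3cccc(Cl)c3)NC2=O)cc1` gives 1250 nM
Compound 2 `COc1ccc(/C=C2/S/C(=N/c3ccccc3C)NC2=O)cc1` gives 1700 nM
Compound 3 `Cc1ccc(N=C2NC(=O)/C(=C\c3ccc(N(C)C)cc3)S2)cc1` gives 820 nM

In a functional assay on NCI-H460 cells (Homo sapiens) for antiproliferative activity (on this read-out higher numbers stand for weaker inhibition and lower numbers for stronger inhibition), compound 3 (820 nM) stays within the usual scatter of compound 1 (1250 nM), while compound 2 (1700 nM) gives a higher number by a gap only just beyond that scatter. Compound 4 `CN(C)c1ccc(/C=C2/SC(=Nc3ccccc3Cl)NC2=O)cc1` has not yet been measured. Compared with compound 3, it has 2-chlorophenyl in place of 4-methylphenyl on a double-bonded nitrogen. Among the measured compounds shown here, no two measured compounds differ in one place only, so this swap has no direct guide. The nearest hint is indirect: compound 1 (1250 nM) and compound 2 (1700 nM) carry other groups on that nitrogen, differ elsewhere too, and still stay near compound 3. In this assay no step beyond the scatter is therefore expected, with a slightly higher number the likelier direction. The estimated change is a 1.2-fold higher number from compound 3 to compound 4 (0.09 log units; within the scatter) as a small one. For compound 4 the estimated value is 1000 nM with an expected range from 450 nM to 2200 nM in a repeat measurement.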

Compound 4, half-maximal inhibitory concentration: 880 nM
For compound 4 the middle estimate is 1.1-fold (0.06 log units) above the measured one; the measured number falls inside the stated range.
By their numbers in this assay, from the lowest: compounds 3, 4, 1 and 2 (each within the scatter of the next, the first and the last beyond it).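

In this assay, among the compounds shown here, the change from 4-methylphenyl to 2-chlorophenyl on a double-bonded nitrogen can be read on its own for the first time (a 1.1-fold higher number from compound 3 to compound 4 (0.03 log units; within the scatter)). With the rest of the molecule held fixed, one substituted phenyl ring can therefore replace the other here without a change that stands out from the scatter of repeat measurements. No measured property of these two groups is available to explain this result.

Both groups compared are phenyl rings with a single substituent, so the compounds shown leave open how a different kind of group on this nitrogen, such as a plain butyl chain or a phenyl ring carrying a carboxylic acid, would read. They also leave open whether the same swap would read alike with the methoxy group of compound 2 in place of the dimethylamino group.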